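Cyclopentyl for methyl on the amine nitrogen of compound 3

This account rests on a few compounds, and the source may have more. Where it says the series, first, only, none or still open, it means among the compounds named here.

For the measured compounds named here, compound 3 `CNN(C)c1nnc(-c2ccccc2C)s1` gives 23 mg/kg in a functional assay on the whole organism with Mus musculus as the target, with a stated time of 1 h (a higher number here means that more compound is needed for the effect, a lower number that less compound is needed), the lowest of the three numbers so far, but its steps to compound 1 `Cc1ccccc1-c1nnc(NN)s1` with 30 mg/kg and to compound 2 `Cc1ccccc1-c1nnc(N(C)N)s1` with 41 mg/kg both stay within the scatter. Compound 4 `Cc1ccccc1-c1nnc(N(C)NC2CCCC2)s1` differs from compound 3 by cyclopentyl in place of methyl on an amine nitrogen. Going by the values given here, the steps that bear on this site are small: a 1.8-fold lower number from compound 2 to compound 3 (0.25 log units; within the scatter), a 1.4-fold higher number from compound 1 to compound 2 (0.14 log units; within the scatter) and a 1.3-fold lower number from compound 1 to compound 3 (0.12 log units; within the scatter), all within the scatter. Among the compounds with values here, no measured compound carries anything larger than methyl on the amine nitrogen, so the cyclopentyl is untested ground. On this evidence the change is expected to be a 1.1-fold higher number from compound 3 to compound 4 (0.04 log units; within the scatter), with no direction beyond the scatter. Compound 4 is therefore expected to give 25 mg/kg, with a range from 10 mg/kg to 65 mg/kg.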

Compound 4, dose for half-maximal effect: 81 mg/kg
For compound 4 the middle estimate is 3.2-fold (0.51 log units) below the measured one; the whole stated range lies below it.
By their numbers in this assay, from the lowest: compounds 3, 1, 2 and 4 (each within the scatter of the next, the first and the last beyond it).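

In this assay the amine nitrogen shows its first step beyond the scatter, with cyclopentyl in place of methyl giving a 3.5-fold higher number from compound 3 to compound 4 (0.55 log units; beyond the scatter) and so a clear cost against the methyl group. Measured against hydrogen on the same nitrogen, cyclopentyl stays within the scatter, with a 2.0-fold higher number from compound 2 to compound 4 (0.30 log units; within the scatter) and no firm cost. Nothing shown gives a cause for either step.

Open, on these data alone, is whether an ethyl group, a longer chain or a cyclopropyl ring on this nitrogen would read like methyl in compound 3 or like cyclopentyl in compound 4.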